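A Carbonyl Substituent Exchange and Growth Inhibition

The source may hold more compounds than are shown below. What is called first, only, known or untested is meant among the compounds shown, and "the series" means these compounds.

In a functional assay on UACC-257 cells (Homo sapiens) for inhibition, read by sulforhodamine B assay, with a stated time of 48 h (a lower number here means a stronger inhibitor of growth, a higher number a weaker inhibitor of growth), compound 2 (`COc1cc(-c2nn(-c3cccc(NC(=O)Nc4ccc(Cl)c(Cl)c4)c3)cc2-c2ccncc2)ccc1Cl`) gives 1040 nM, the lower of two numbers, while compound 1 (`COc1cc(-c2nn(-c3cccc(NC(=O)c4cccc(C(F)(F)F)c4)c3)cc2-c2ccncc2)ccc1Cl`) gives 27900 nM. Compound 3 (`COc1cc(-c2nn(-c3cccc(NC(=O)c4ccc(Cl)c(C(F)(F)F)c4)c3)cc2-c2ccncc2)ccc1Cl`) carries 4-chloro-3-(trifluoromethyl)phenyl in place of (3,4-dichlorophenyl)amino on a carbonyl carbon. Going by the values given here, one measured step bears on this: the large 27-fold lower number from compound 1 to compound 2 (1.43 log units; beyond the scatter), made at that same carbon. Like compound 1, compound 3 lacks (3,4-dichlorophenyl)amino, so part of that step should be undone. The expected change is a 5.8-fold higher number from compound 2 to compound 3 (0.76 log units; beyond the scatter), towards a higher number. Compound 3 is estimated at 6000 nM, within a range of 1500 nM to 25000 nM.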

Compound 3, concentration for 50% growth inhibition: 7130 nM
The estimate for compound 3 lay 1.2-fold (0.07 log units) below the measured number; measured number inside the range.
By their numbers in this assay, from the lowest: compound 2; then compound 3; then compound 1.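

In this assay, chloro in place of hydrogen on an aromatic carbon gives a 3.9-fold lower number from compound 1 to compound 3 (0.59 log units; beyond the scatter), so this ring can shift the number without (3,4-dichlorophenyl)amino being present. Even so, 4-chloro-3-(trifluoromethyl)phenyl on the carbonyl carbon does not match that group, with a 6.9-fold higher number from compound 2 to compound 3 (0.84 log units; beyond the scatter) in the same assay. No measurement offered here accounts for either step.

As far as these compounds go, it remains open whether (4-chloro-3-(trifluoromethyl)phenyl)amino on this carbonyl carbon would give a lower number than compound 3. From the compounds shown here alone, the effect of a nitrile or a methoxy group in place of the chloro also remains open.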